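This account rests on a few compounds, and the source may have more. Where it says the series, first, only, none or still open, it means among the compounds named here.

Of the compounds shown here, three built on one shared core have been measured in a functional assay on A549 cells (Homo sapiens) for cytotoxicity, read by MTT assay, with a stated time of 72 h; a higher number here means that more compound is needed for the effect, a lower number that less compound is needed. Compound 1 `CCc1cccc2c(OC)c(-c3occ(C)c3C(=O)OC)ccc12` gives 1.5 ug/mL in this assay. Compound 2 `CCOc1c(-c2occ(C)c2C(=O)OC)ccc2c(CC)cccc12` differs from compound 1 by a methyl in place of hydrogen on a saturated chain carbon bound to an oxygen on an aromatic ring. In this assay compound 2 gives 2.4 ug/mL; that step, a 1.6-fold higher number from compound 1 to compound 2 (0.20 log units; within the scatter), leaves the two numbers indistinguishable, and compound 2 stands as the highest of the two plain numbers shown. Compound 3 `CCOCc1c(C)coc1-c1ccc2c(CC)cccc2c1OC` reaches only a limit of the assay, > 10 ug/mL, in this assay.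

Compound 4 `CCOc1c(-c2occ(C)c2COC)ccc2c(CC)cccc12` is not yet measured. It differs from compound 2 by methoxymethyl in place of methoxycarbonyl on an aromatic carbon. Among the measured compounds shown here, the one measured step that bears on this change is the ethoxymethyl in place of methoxycarbonyl, an at least 6.6-fold higher number from compound 1 to compound 3 (0.82 log units; beyond the scatter), which ran into (the limit of > 10 ug/mL in this assay, at which 1 of the 3 values shown sits). A very similar loss of the methoxycarbonyl group in compound 4 is therefore expected to raise the number well beyond the scatter, most likely again to a limit rather than a plain number.

The expected step, a 7.5-fold higher number from compound 2 to compound 4 (0.88 log units; beyond the scatter), is a clear rise. Compound 4 is estimated at about 18 ug/mL in this assay, with a likely range from 6 ug/mL to 50 ug/mL.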

Compound 4, concentration for half-maximal effect: > 10 ug/mL
Compound 4 was reported as a limit; the forecaster's own chance of this, stated with the estimate: 70%; the middle value does not contradict the limit.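

Compound 4 gives > 10 ug/mL in this assay, which is a limit of the assay and not a plain number. Replacing methoxycarbonyl with methoxymethyl on this aromatic carbon still gives a clear step, an at least 4.1-fold higher number from compound 2 to compound 4 (0.61 log units; beyond the scatter), so the rise seen earlier with ethoxymethyl also appears with a shorter replacement group and on a second parent compound, one that carries an extra methyl on the chain bound through oxygen to the aromatic ring. Among the compounds shown, both replacements of methoxycarbonyl at this place end at the same assay limit, and neither goes against this pattern: the limit of > 10 ug/mL in this assay, at which 2 of the 4 values shown sit.

From the compounds shown here alone, since both results are limits, the true size of each rise remains unknown, and the two replacement groups cannot be ranked against each other. Going by these compounds, it also remains open which part of methoxycarbonyl matters at this position, a question that a carboxylic acid, a primary amide or a simple ketone on the same aromatic carbon could help to answer.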